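Benzylthio aryl variation: compound 4 from compound 3

The source may hold more compounds than are shown below. What is called first, only, known or untested is meant among the compounds shown, and "the series" means these compounds.

The series shares one core and varies the aryl group on the benzylic sulfur. Compound 1 `Cc1cc(S(=O)(=O)/N=C(\N)n2nccc2-c2ccccc2)c(SCc2cccc(Cl)c2)cc1Cl` is measured in an ADME assay on microsomes from liver (Homo sapiens) for metabolic stability, read by LC-MS, using NADPH, tested at 5 uM (a higher number here means that the compound lasts longer, a lower number that the compound disappears faster), and gives 0.309 h. Compound 2 `Cc1cc(S(=O)(=O)/N=C(\N)n2nccc2-c2ccccc2)c(SCc2ccc(C(F)(F)F)cc2)cc1Cl` gives 0.176 h, and compound 3 `Cc1cc(S(=O)(=O)/N=C(\N)n2nccc2-c2ccccc2)c(SCc2ccccc2C)cc1Cl` gives 0.0802 h. Compound 3 therefore holds the lowest number of the three: the step of a 3.9-fold lower number from compound 1 to compound 3 (0.59 log units; beyond the scatter) is beyond the scatter, as is the step of a 2.2-fold lower number from compound 2 to compound 3 (0.34 log units; beyond the scatter), while the step of a 1.8-fold lower number from compound 1 to compound 2 (0.24 log units; within the scatter) stays within it.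

Compound 4 `Cc1cc(S(=O)(=O)/N=C(\N)n2nccc2-c2ccccc2)c(SCc2ccccc2C(F)(F)F)cc1Cl` has not yet been measured. It differs from compound 3 by trifluoromethyl in place of methyl on an aromatic carbon. Among the compounds with values here, none of the measured steps makes this exact change; the only step that introduces a trifluoromethyl group is the one from compound 1 to compound 2, where it enters at another place on the ring and the number moves within the scatter. Compound 2, which carries that group, gives a higher number than compound 3, and this is the only point of reference. For compound 4 the step is expected to be a 1.7-fold higher number from compound 3 to compound 4 (0.24 log units; within the scatter), an increase that may not clear the scatter. Compound 4 is accordingly estimated at 0.14 h, with a range from 0.07 h to 0.3 h.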

Compound 4, half-life: 0.15 h
The estimate for compound 4 lay 1.1-fold (0.03 log units) below the measured number, and the stated range covers the measured number.
By their numbers in this assay, from the lowest: compounds 3, 4, 2 and 1 (each within the scatter of the next, the first and the last beyond it).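

In this assay the change at this position, on an aromatic carbon ortho to a large group, can now be read directly: the step of a 1.9-fold higher number from compound 3 to compound 4 (0.27 log units; within the scatter) stays within the scatter, so trifluoromethyl in place of methyl cannot be told apart from no change here, even though compound 3 stood beyond the scatter from both compound 1 and compound 2. The trifluoromethyl pair adds a second reading, as the step of a 1.2-fold lower number from compound 2 to compound 4 (0.07 log units; within the scatter) also stays within the scatter and the two placements of that group on the ring are not separated, while the step of a 2.1-fold lower number from compound 1 to compound 4 (0.31 log units; beyond the scatter) lies beyond the scatter and sets compound 4, unlike compound 2, apart from compound 1. No supporting data bear on why these numbers fall as they do.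

On these data alone, how an amine or a carboxylic acid on this ring, or a longer chain between the sulfur and the ring, would read in this assay stays open. As far as these compounds go, the shared core is constant throughout, so whether these steps would carry over to another core also stays open.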